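The source may hold more compounds than are shown below. What is called first, only, known or untested is meant among the compounds shown, and "the series" means these compounds.

Measured compounds and their values:

Compound 1, `COc1cccc(N(Cc2cn([C@@H]3O[C@H](COC(C)=O)[C@@H](OC(C)=O)[C@H]3OC(C)=O)nn2)S(C)(=O)=O)c1`, in a functional assay on MDA-MB-231 cells (Homo sapiens) for antiproliferative activity, read by XTT assay, with a stated time of 48 h (on this read-out lower numbers stand for stronger inhibition and higher numbers for weaker inhibition), compound 1 gives 160000 nM.
Compound 2, `CC(=O)OC[C@H]1O[C@@H](n2cc(CN(c3ccc(C#N)cc3)S(C)(=O)=O)nn2)[C@H](OC(C)=O)[C@@H]1OC(C)=O`, in this assay compound 2 gives 100000 nM.
Compound 3, `COc1cccc(N(Cc2cn([C@@H]3O[C@H](COC(C)=O)[C@@H](OC(C)=O)[C@H](OC(C)=O)[C@H]3OC(C)=O)nn2)S(C)(=O)=O)c1`, in this assay compound 3 gives 220000 nM.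

Compounds 1 and 2 share one core and differ in a single place. The change is 4-cyanophenyl in place of 3-methoxyphenyl on a sulfonamide nitrogen. It made the step of a 1.6-fold lower number from compound 1 to compound 2 (0.20 log units; within the scatter), so the two numbers cannot be told apart.

Compound 3 carries a second core, and the difference between the two cores is not broken down here. Compound 4, `CC(=O)OC[C@H]1O[C@@H](n2cc(CN(c3ccc(C#N)cc3)S(C)(=O)=O)nn2)[C@H](OC(C)=O)[C@@H](OC(C)=O)[C@@H]1OC(C)=O`, has not yet been measured in this assay. It stands to compound 3 as compound 2 stands to compound 1: the change is 4-cyanophenyl in place of 3-methoxyphenyl on a sulfonamide nitrogen, at the same place with the same neighbours, so it is the same change made on the other core.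

Going by the values given here, the only guide is the step seen on the first core. Because a 1.6-fold lower number from compound 1 to compound 2 (0.20 log units; within the scatter) was within the scatter, the expected step is a 1.6-fold lower number from compound 3 to compound 4 (0.20 log units; within the scatter), and the expected number for compound 4 in this assay is 140000 nM, most likely between 70000 nM and 280000 nM. Compound 3 sits at the high end of what is measured, so compound 4 may also come out as a limit rather than a number.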

Compound 4, half-maximal inhibitory concentration: 215000 nM
For compound 4 the middle estimate is 1.5-fold (0.19 log units) below the measured one; the range from low to high includes it.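

In this assay putting 4-cyanophenyl in place of 3-methoxyphenyl on the sulfonamide nitrogen gives a 1.0-fold lower number from compound 3 to compound 4 (0.01 log units; within the scatter) so these two numbers cannot be told apart. Set beside the earlier step, the change reads the same on both cores within what this measurement can resolve: the same change on two cores in this assay, a 1.6-fold lower number (0.20 log units; within the scatter) from compound 1 to compound 2 and a 1.0-fold lower number (0.01 log units; within the scatter) from compound 3 to compound 4, 1.6-fold (0.19 log units) apart, within the scatter of two such steps. Going by these compounds alone, this shows only that the swap produced no readable shift on either core; it does not show that the change has no effect at all, since a small one could hide within the scatter, and two cores make no general rule.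

The compounds shown leave open whether a different group on the phenyl ring, such as an amine or a carboxylic acid, would move the number beyond the scatter on either core. They also leave open what free hydroxyl groups in place of the acetate esters on the sugar-like core would do.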